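The source may report more compounds than this note shows. Statements on the series, on what has been measured and on what is new or still open speak of the compounds shown alone.

Measured compounds:
compound 1 `CN(c1ncco1)c1cnc(NCc2c(F)ccc3c2CCO3)n2cnnc12`: 67000 nM
compound 2 `CC(=O)N1CCC(c2cnc(NCc3c(F)ccc4c3CCO4)c3cn[nH]c(=O)c23)CC1`: < 2000 nM, a limit of the assay
compound 3 `Cc1ncccc1-c1cnc(NCc2c(F)ccc3c2CCO3)c2cn[nH]c(=O)c12`: < 2000 nM, a limit of the assay

Among the measured compounds shown here, in a physicochemical assay for solubility, read by LC-MS, in phosphate buffer, with a stated time of 24 h, at pH 7.4 (on this read-out lower numbers stand for lower solubility and higher numbers for higher solubility), compound 1 gives 67000 nM, the only number among the three values. Compound 2 sits at the limit of < 2000 nM in this assay, at which 2 of the 3 values shown sit. Compound 3 sits at the same limit. For the measured compounds named here, the one step between measured compounds, a step that the two limits leave unreadable from compound 2 to compound 3, runs between two limits and cannot be read; it also lies on the other core, so it does not bear on the change considered here.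

Compound 4 `CN(c1cccnc1)c1cnc(NCc2c(F)ccc3c2CCO3)n2cnnc12` keeps the core of compound 1 and differs by pyridin-3-yl in place of 1,3-oxazol-2-yl on a nitrogen on an aromatic ring. Going by the values given here, no measured step covers this change, so no direction beyond the usual scatter can be read from the data; the expectation therefore rests on compound 1 alone. The step of a 1.7-fold lower number from compound 1 to compound 4 (0.22 log units; within the scatter) is expected to stay within the scatter. Compound 4 is estimated at 40000 nM, within a range of 12000 nM to 130000 nM, in this assay.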

Compound 4, solubility: 47000 nM
Compound 4: middle estimate off by 1.2-fold (0.07 log units), on the low side; the range from low to high includes it.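

In this assay, among the compounds shown here, the change at this position gives a 1.4-fold lower number from compound 1 to compound 4 (0.15 log units; within the scatter), the only readable step on the core of compound 1. At this nitrogen on an aromatic ring, the read-out does not separate 1,3-oxazol-2-yl, a five-membered aromatic ring with 2 hetero atoms, from pyridin-3-yl, a six-membered aromatic ring with 1 hetero atom. No measured property shown bears on the origin of this small step.

From the compounds shown here alone, whether a non-aromatic group in this place, such as a saturated chain carrying an amine or a carboxylic acid, would move the solubility beyond the scatter remains open. For the compounds shown here, the one step on the other core cannot be read, and whether this change would behave alike on that core also remains open.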